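A few compounds are considered here, and "the series" means these few. Any claim that something is new, unique, unknown or untested is made for them only; others in the source may bear on it.

Measured compounds:
Compound 1, `Cc1ccc(-n2nncc2CN2C(=O)C3(C(C#N)=C(N)Oc4c3c3nc5ccccc5nc3c3ccccc43)c3ccccc32)cc1C`, gives > 50000 nM in a functional assay on A549 cells (Homo sapiens) for antiproliferative activity, read by MTT assay, with a stated time of 48 h; on this read-out higher numbers stand for weaker inhibition and lower numbers for stronger inhibition.
Compound 2, `Cc1cc(C)cc(-n2nncc2CN2C(=O)C3(C(C#N)=C(N)Oc4c3c3nc5ccccc5nc3c3ccccc43)c3ccccc32)c1`, gives > 50000 nM.
Compound 3, `COc1ccc(-n2nncc2CN2C(=O)C3(C(C#N)=C(N)Oc4c(N)cc5nc6ccccc6nc5c43)c3ccccc32)cc1`, gives > 50000 nM.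

Each of these three values is a limit of this assay and not a number: the limit of > 50000 nM in this assay, at which 3 of the 3 values shown sit. For that reason the step that the two limits leave unreadable from compound 1 to compound 2 cannot be read, and nothing about its size is known. Compound 3 stands on the same limit as the other two compounds; the numbers shown do not separate it from them.

Compound 4, `N#CC1=C(N)Oc2c(N)cc3nc4ccccc4nc3c2C12C(=O)N(Cc1cnnn1-c1cc(Cl)ccc1Cl)c1ccccc12`, has not yet been measured. It differs from compound 3 by 2,5-dichlorophenyl in place of 4-methoxyphenyl on an aromatic nitrogen. Among the compounds with values here, the one measured step, a step that the two limits leave unreadable from compound 1 to compound 2, also swaps the group on the aromatic nitrogen, but it is unreadable and so gives no size to carry over. Because compound 3 sits at > 50000 nM, compound 4 is expected to remain at that limit as well. The expected step is a number no higher from compound 3 to compound 4 (the limit leaves the size open), which means no change beyond the scatter. Compound 4 is therefore estimated at 50000 nM, with a range from 20000 nM to 200000 nM.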

Compound 4, half-maximal inhibitory concentration: 10900 nM
For compound 4 the middle estimate is 4.6-fold (0.66 log units) above the measured one; measured number outside the range, below it.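

In this assay, within the data shown here, 2,5-dichlorophenyl in place of 4-methoxyphenyl on the aromatic nitrogen gives an at least 4.5-fold lower number from compound 3 to compound 4 (0.66 log units; beyond the scatter), the first readable step in this set, which shows that the group at this position can shift the read-out beyond the scatter. Compound 3 carries a limit of the assay, > 50000 nM, and not a number. No earlier step could show this, because none could be read, with every earlier value sitting on the same limit: the limit of > 50000 nM in this assay, at which 3 of the 4 values shown sit.

The compounds shown do not tell whether a single chlorine would do the same, as in a 4-chlorophenyl group, or how an unsubstituted phenyl would read at this position. They also leave open whether 2,5-dichlorophenyl would lower the number on the core of compound 1.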